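This account rests on a few compounds, and the source may have more. Where it says the series, first, only, none or still open, it means among the compounds named here.

The shared core of these compounds carries a phenyl group and one variable substituent. Compound 1 `Nc1cc(N)c2nc(-c3ccccc3)c(NCc3ccc(Cl)c(Cl)c3)nc2c1` was tested in a functional assay on OVCAR-8 cells (Homo sapiens) for inhibition, read by sulforhodamine B assay, with a stated time of 48 h; on this read-out lower numbers stand for higher toxicity in this test and higher numbers for lower toxicity in this test. In this assay compound 1 gives only a limit, < 100000 nM. Compound 2 `Nc1cc(N)c2nc(-c3ccccc3)c(NCc3ccc(F)cc3)nc2c1` gives 21900 nM in this assay. Compound 3 `COc1ccc(Sc2nc3cc(N)cc(N)c3nc2-c2ccccc2)cc1` likewise gives only a limit in this assay, < 100000 nM. Where compound 3 stands is thus known only as a limit, and the limit of < 100000 nM in this assay, at which 2 of the 3 values shown sit, shows where it sits. The step that the limit leaves unreadable from compound 1 to compound 2 and the step that the limit leaves unreadable from compound 2 to compound 3 both remain unreadable, so neither yields a size or a direction. Compound 4 `Nc1cc(N)c2nc(-c3ccccc3)c(Oc3ccc(F)cc3)nc2c1` differs from compound 3 by 4-fluorophenoxy in place of (4-methoxyphenyl)sulfanyl on an aromatic carbon. Among the measured compounds shown here, no measured step covers this exchange, and the only numbered value belongs to compound 2, which also carries a fluorine-bearing ring. Because compound 2 gives 21900 nM in this assay, compound 4 is expected near 30000 nM, with a range from 8000 nM to 100000 nM. This expectation amounts to a step that the limit leaves unreadable from compound 3 to compound 4, a step that starts from a limit and is therefore loosely fixed.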

Compound 4, concentration lethal to 50% of the cells: 100000 nM
The estimate for compound 4 lay 3.3-fold (0.52 log units) below the measured number; the measured number falls inside the stated range.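

In this assay, among the compounds shown here, 4-fluorophenoxy in place of (4-fluorobenzyl)amino on this aromatic carbon gives a 4.6-fold higher number from compound 2 to compound 4 (0.66 log units; beyond the scatter), the first step at this position with a number at both ends, and here the higher number stands for lower toxicity in this test. The position therefore responds to the group it carries, though this rests on a single pair of compounds. In this assay, 4-fluorophenoxy in place of (4-methoxyphenyl)sulfanyl on the same carbon gives a number no lower from compound 3 to compound 4 (the limit leaves the size open), a step that starts from a limit. Compound 1 and compound 3 remain limits of the assay, and the steps from compound 1 to compound 2 and from compound 2 to compound 3 cannot be read: the limit of < 100000 nM in this assay, at which 2 of the 4 values shown sit.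

The exchange from compound 2 to compound 4 alters the link to the ring and the length of that link at once, so the compounds shown do not separate the two. Going by these compounds, how a simple amine or a longer chain on this carbon would read also stays open.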